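A Cyano Group Takes the Place of Methylsulfonyl

The compounds below may be only part of what the source reports. "The series", "measured", "known", "first", "only" and "open" are said of these compounds alone.

The series shares one core, varied only in the aryl group on the ring nitrogen. Compound 1 `CC(C)OC(=O)N1CCC(Oc2ncnc3c2CCN3c2ccc(S(C)(=O)=O)cc2F)CC1` carries a 2-fluoro-4-(methylsulfonyl)phenyl group; in a functional assay on CHO-K1 cells for agonist activity at Glucose-dependent insulinotropic receptor (Homo sapiens), read by a luciferase reporter, with a stated time of 5 h (a higher number here means that more compound is needed for the effect, a lower number that less compound is needed), compound 1 gives 50.1 nM. Compound 2 `CC(C)OC(=O)N1CCC(Oc2ncnc3c2CCN3c2ccc(S(C)(=O)=O)cc2)CC1` lacks the fluoro, and in this assay compound 2 gives 126 nM, a step of a 2.5-fold higher number from compound 1 to compound 2 (0.40 log units; beyond the scatter). Compound 3 `CC(C)OC(=O)N1CCC(Oc2ncnc3c2CCN3c2ccc(S(C)(=O)=O)cn2)CC1` bears a 5-(methylsulfonyl)pyridin-2-yl group instead, and compound 3 gives 126 nM. Compound 3 thus stands level with compound 2, with no change at the digits printed from compound 2 to compound 3 (within the scatter), while the step of a 2.5-fold higher number from compound 1 to compound 3 (0.40 log units; beyond the scatter) sets compound 3 apart from compound 1.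

Compound 4 `CC(C)OC(=O)N1CCC(Oc2ncnc3c2CCN3c2ccc(C#N)cn2)CC1` differs from compound 3 by cyano in place of methylsulfonyl on an aromatic carbon. None of the three measured steps touches the methylsulfonyl group itself: two concern the fluoro and one the ring nitrogen, and both kinds of change moved the number by modest amounts at most. Going by the values given here, no measured step therefore bears directly on the exchange of methylsulfonyl for cyano, and the expectation rests on the unchanged core alone. The number for compound 4 in this assay is estimated to stay near that of compound 3, with wide uncertainty, a step of a 1.6-fold higher number from compound 3 to compound 4 (0.20 log units; within the scatter). Compound 4 is thus expected to give about 200 nM, within a range from 60 nM to 700 nM.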

Compound 4, half-maximal effective concentration: 794 nM
Beside the measured number, compound 4's estimate is 4.0-fold (0.60 log units) below it, and the stated range ends below it.
By their numbers in this assay, from the lowest: compound 1; then compounds 2 and 3 (each within the scatter of the next); then compound 4.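

In this assay, the exchange of methylsulfonyl for cyano is the first change shown on this aromatic carbon, and it gives a 6.3-fold higher number from compound 3 to compound 4 (0.80 log units; beyond the scatter). Going by these compounds alone, that moves the number further than the fluoro change did, and further than the ring nitrogen change, which left it unmoved within the scatter, so of the places varied so far this carbon is the one where the number responds most. Within the data shown here, the change to 5-cyanopyridin-2-yl also gives a 6.3-fold higher number from compound 2 to compound 4 (0.80 log units; beyond the scatter) and, the only step in the set printed as large, a 16-fold higher number from compound 1 to compound 4 (1.20 log units; beyond the scatter), so on this ring cyano does not stand in for methylsulfonyl at equal effect.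

No measurement offered here accounts for the size of this step. The compounds shown leave open whether cyano would cost as much on the 2-fluoro-4-substituted phenyl group of compound 1, and how the number would respond on this carbon to a sulfonamide, a primary amide, a methyl ester or a longer alkylsulfonyl chain such as ethylsulfonyl.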